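Dimethylcarbamoyl in place of pyridinyl on the fused core

The source may hold more compounds than are shown below. What is called first, only, known or untested is meant among the compounds shown, and "the series" means these compounds.

Compound 2 `CCCCN(c1nc2c(-c3ccccn3)cccc2o1)[C@H](C)c1ccc(-c2ccccc2-c2nnn[nH]2)cc1` gives 0.00129 in an ADME assay on the whole organism (plasma, Macaca fascicularis) for protein binding, read by LC-MS, using equilibrium dialysis and cassette dosing, with a stated time of 24 h, at a dose of 1 mg/kg by the oral route (a lower number here means a smaller unbound share, a higher number a larger unbound share of the compound), the higher of the two numbers in hand; compound 1 `CCCCN(c1nc2c(NS(C)(=O)=O)cccc2o1)[C@H](C)c1ccc(-c2ccccc2-c2nnn[nH]2)cc1` gives 0.000203, and the step of a 6.4-fold higher number from compound 1 to compound 2 (0.80 log units; beyond the scatter) is beyond the scatter. Compound 3 `CCCCN(c1nc2c(C(=O)N(C)C)cccc2o1)[C@H](C)c1ccc(-c2ccccc2-c2nnn[nH]2)cc1` carries the change (dimethylcarbamoyl in place of pyridin-2-yl on an aromatic carbon), on an aromatic carbon of the fused core, ortho to a fused ring. No measured step covers this exchange, and the one step shown bears only indirectly. A step within the scatter, a 1.2-fold higher number from compound 2 to compound 3 (0.07 log units; within the scatter), is therefore expected. Compound 3 is estimated at 0.0015, in the range 0.0005 to 0.005.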

Compound 3, unbound fraction: 0.00411
For compound 3 the middle estimate is 2.7-fold (0.44 log units) below the measured one; the measured number falls inside the stated range.
By their numbers in this assay, from the lowest: compound 1; then compound 2; then compound 3.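

At this aromatic carbon, a group with no ring raises the number: dimethylcarbamoyl in place of pyridin-2-yl gives a 3.2-fold higher number from compound 2 to compound 3 (0.50 log units; beyond the scatter) in this assay. Dimethylcarbamoyl in place of methanesulfonamido gives a 20-fold higher number from compound 1 to compound 3 (1.31 log units; beyond the scatter) and leaves compound 3 with the largest unbound share of the three. Nothing measured here accounts for either step.

Going by these compounds, whether another amide, such as methylcarbamoyl, would give a number like that of compound 3 remains open. So does where a carboxylic acid or an amine at this carbon would fall.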